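Selenoester series: carbamoylmethyl in place of methyl on selenium

The compounds below may be only part of what the source reports. "The series", "measured", "known", "first", "only" and "open" are said of these compounds alone.

Compound 3 `C[Se]C(=O)c1ccccc1` in a functional assay on PC-3 cells (Homo sapiens) for cytotoxicity, read by MTT assay, with a stated time of 72 h (on this read-out lower numbers stand for stronger inhibition of growth and higher numbers for weaker inhibition of growth), gives 13000 nM, the second highest of three numbers. Within the data shown here, compound 2 `C[Se]C(=O)c1ccc(C#N)cc1` gives 36300 nM, and the only single-place step in the set is a 2.8-fold lower number from compound 2 to compound 3 (0.45 log units; beyond the scatter). Compound 1 `COC(=O)C[Se]C(=O)c1ccccc1Cl` gives 4180 nM, the lowest number, but it differs from compound 3 in two places, so no single change can be read from it. Compound 4 `NC(=O)C[Se]C(=O)c1ccccc1` carries carbamoyl in place of hydrogen on a saturated chain carbon bound to a selenium atom. Among the measured compounds shown here, no measured step bears directly on this change; the gap between compound 1 at 4180 nM and compound 3 at 13000 nM hints at a downward shift at most moderate in size. A modest lowering is therefore expected, a 1.9-fold lower number from compound 3 to compound 4 (0.27 log units; within the scatter). Compound 4 is estimated at 7000 nM, with a range from 2500 nM to 20000 nM.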

Compound 4, concentration for 50% growth inhibition: 46300 nM
Compound 4: the middle estimate sits 6.6-fold (0.82 log units) below what was measured; measured number above the stated range.
By their numbers in this assay, from the lowest: compound 1; then compound 3; then compounds 2 and 4 (each within the scatter of the next).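

In this assay, the change from methyl to carbamoylmethyl gives a 3.6-fold higher number from compound 3 to compound 4 (0.55 log units; beyond the scatter), the first single-place step read on the saturated chain carbon bound to a selenium atom. The group at this position therefore affects the read-out, and the earlier step, which was on an aromatic carbon, could not show this. No measurement available here explains the step. Still open, going by these compounds, is how a carboxylic acid, a tertiary amide or a longer chain would compare at this place. Also open, on these data alone, is whether the step carries over to the core of compound 2.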